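The source may hold more compounds than are shown below. What is called first, only, known or untested is meant among the compounds shown, and "the series" means these compounds.

Of the compounds shown here, two built on a shared core have been tested in a functional assay on HCT-116 cells (Homo sapiens) for cytotoxicity, read by MTT assay, with a stated time of 48 h; on this read-out higher numbers stand for weaker inhibition and lower numbers for stronger inhibition. Compound 1 `COc1cc(/C=C/C(=O)C2=C(/C=C/c3ccc(O)c(OC)c3)NC(=O)NC2c2ccc(C)cc2)ccc1O` gives 12500 nM in this assay. Compound 2 `COc1cc(/C=C/C(=O)C2=C(/C=C/c3ccc(O)c(OC)c3)NC(=S)NC2c2ccccc2)ccc1O` gives 100000 nM in this assay, the higher of the two numbers, with compound 1 lying beyond the usual scatter below it. Compound 3 `COc1cc(/C=C/C(=O)C2=C(/C=C/c3ccc(O)c(OC)c3)NC(=S)NC2c2ccccc2O)ccc1O` has not been measured; it differs from compound 2 by hydroxy in place of hydrogen on an aromatic carbon. Neither measured compound shows what such a change does, so the step in this assay is expected to be small or within the scatter, estimated as a 1.3-fold lower number from compound 2 to compound 3 (0.10 log units; within the scatter). Compound 3 is therefore expected at 80000 nM, within a range of 30000 nM to 150000 nM.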

Compound 3, half-maximal inhibitory concentration: 100000 nM
For compound 3 the middle estimate is 1.3-fold (0.10 log units) below the measured one; the range from low to high includes it.
By their numbers in this assay, from the lowest: compound 1; then compounds 2 and 3 (each within the scatter of the next).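

In this assay, the change from phenyl to 2-hydroxyphenyl, with hydroxy ortho to a large group, gives no change at the digits printed from compound 2 to compound 3 (within the scatter). Going by these compounds alone, compound 1 and compound 2 differ in more than one place, so only this pair isolates the effect of adding hydroxy here, and it adds no measurable cytotoxicity. Nothing available explains this result.

As far as these compounds go, whether an amine or a carboxylic acid on this aromatic carbon would give a different number remains open. The separate contributions of the differences between compound 1 and compound 2 cannot be read.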